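This account rests on a few compounds, and the source may have more. Where it says the series, first, only, none or still open, it means among the compounds named here.

Measured so far:
- compound 1, `COc1ccc(CS(=O)(=O)/C=C/c2ccc(OC)c(OC)c2OC)cc1[N+](=O)[O-]`, which in a functional assay on HCT-116 cells (Homo sapiens) for cytotoxicity, read by MTT assay, with a stated time of 72 h (on this read-out lower numbers stand for stronger inhibition of growth and higher numbers for weaker inhibition of growth), gives 27900 nM
- compound 2, `COc1ccc(CS(=O)(=O)/C=C/c2ccc(OC)c(OC)c2OC)cc1N`, which in this assay gives 5310 nM
- compound 3, `COc1ccc(CS(=O)(=O)CC(=O)Nc2ccccc2)cc1[N+](=O)[O-]`, for which this assay reports only a limit, > 30000 nM

Compound 1 and compound 2 share one core and differ in one place: amino in place of nitro on an aromatic carbon. That change produced a 5.3-fold lower number from compound 1 to compound 2 (0.72 log units; beyond the scatter). Compound 3 stands on a different core; the difference between the core of compound 1 and the core of compound 3 is not broken down here. The value of compound 3 is a limit of this assay and not a number, namely (the limit of > 30000 nM in this assay, at which 1 of the 3 values shown sits).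

Compound 4, `COc1ccc(CS(=O)(=O)CC(=O)Nc2ccccc2)cc1N`, is not yet measured. It differs from compound 3 in exactly the way compound 2 differs from compound 1: amino in place of nitro on an aromatic carbon, with the same surroundings of the place, so this is the same change made a second time.

For compound 4 in this assay the expected step is an at least 1.6-fold lower number from compound 3 to compound 4 (0.22 log units; that floor lies within the scatter), set beside the measured 5.3-fold lower number from compound 1 to compound 2 (0.72 log units; beyond the scatter). This expectation rests on that single measured step alone; it is weakened by the fact that compound 3 sits at the limit, so the starting point of the second step is not known as a number, and a second limit cannot be ruled out. On that basis compound 4 is estimated at 18000 nM in this assay, with an expected range from 5000 nM to 60000 nM.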

Compound 4, concentration for 50% growth inhibition: > 30000 nM
Compound 4 ended at the assay's limit (the forecaster's own chance of this, stated with the estimate: 45%); at least 1.6-fold (0.22 log units) between middle value and limit.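

In this assay compound 4 gives > 30000 nM and this is a limit, not a number. Within the data shown here, compound 3 sits at the same limit, so no step between compound 3 and compound 4 can be read: the limit of > 30000 nM in this assay, at which 2 of the 4 values shown sit.

Left open is whether a 5.3-fold lower number from compound 1 to compound 2 (0.72 log units; beyond the scatter) has any counterpart on the core of compound 3, where the size of the change from nitro to amino stays unknown.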